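Replacing an ester with a nitrile-bearing arene

The source may report more compounds than this note shows. Statements on the series, on what has been measured and on what is new or still open speak of the compounds shown alone.

Compound 1 `Cc1cc(C)c(Oc2cc(Nc3ccc(C#N)cc3)ncc2C(=O)NCc2cn(Cc3ccccc3[N+](=O)[O-])nn2)c(C)c1` gives > 212000 nM in an ADME assay on MT4 cells (Homo sapiens) for cytotoxicity, read by MTT assay, with a stated time of 5 days; on this read-out higher numbers stand for lower toxicity in this test and lower numbers for higher toxicity in this test; this value is a limit of this assay.
Compound 2 `Cc1ccc(Cn2cc(CNC(=O)c3cnc(Nc4ccc(C#N)cc4)cc3Oc3c(C)cc(C)cc3C)nn2)cc1` gives 165000 nM in this assay.
Compound 3 `CCOC(=O)Cn1cc(CNC(=O)c2cnc(Nc3ccc(C#N)cc3)cc2Oc2c(C)cc(C)cc2C)nn1` gives 9530 nM in this assay.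

Among these, compound 3 stands lowest: its nearest neighbour is compound 2, and the step of a 17-fold lower number from compound 2 to compound 3 (1.24 log units; beyond the scatter) separates them. Compound 4 `Cc1cc(C)c(Oc2cc(Nc3ccc(C#N)cc3)ncc2C(=O)NCc2cn(Cc3ccccc3C#N)nn2)c(C)c1` is not yet measured; it differs from compound 3 by 2-cyanophenyl in place of ethoxycarbonyl on a saturated chain carbon bound to an aromatic nitrogen. Among the compounds with values here, two measured steps bear on this change. The step of an at least 22-fold lower number from compound 1 to compound 3 (1.34 log units; beyond the scatter) and the step of a 17-fold lower number from compound 2 to compound 3 (1.24 log units; beyond the scatter) both show that replacing a benzyl-type group with the ethoxycarbonyl-bearing chain lowered the number markedly. Compound 4 returns an aromatic ring to that position, so the reverse direction is expected: for compound 4, a step of about a 16-fold higher number from compound 3 to compound 4 (1.20 log units; beyond the scatter) is estimated, giving an expected value near 150000 nM, with a range from 40000 nM to 300000 nM.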

Compound 4, half-maximal cytotoxic concentration: > 219000 nM
Compound 4 ended at the assay's limit; the forecaster's own chance of this, stated with the estimate: 35%; middle value at least 1.4-fold (0.16 log units) from the limit.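

In this assay the value of compound 4 is a limit: the limit of > 219000 nM in this assay, at which 1 of the 4 values shown sits. Placing 2-cyanobenzyl where (ethoxycarbonyl)methyl stood gives an at least 22-fold higher number from compound 3 to compound 4 (1.36 log units; beyond the scatter), so the low number of the ester chain also separates it from a benzyl group bearing a nitrile. Among the benzyl groups, an at least 1.3-fold higher number from compound 2 to compound 4 (0.12 log units; that floor lies within the scatter) sets no order, and the step from compound 1 to compound 4 cannot be read. Going by these compounds, it remains open whether the low number belongs to the ester itself or to non-aromatic chains generally. A carboxylic acid or a plain ethyl chain at this place would tell these apart.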